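Replacing cyano with chloro on the shared core

The compounds below may be only part of what the source reports. "The series", "measured", "known", "first", "only" and "open" are said of these compounds alone.

Measured so far in a functional assay on MC-38 cells (Mus musculus) for antiproliferative activity; on this read-out higher numbers stand for weaker inhibition and lower numbers for stronger inhibition:
compound 1 `N#Cc1ccc(S(=O)(=O)Nc2cccc3c(C#N)c[nH]c23)cc1` gives 0.12 ug/mL here
compound 2 `CS(=O)(=O)Nc1ccc(S(=O)(=O)Nc2cccc3c(C#N)c[nH]c23)cc1` gives 1.2 ug/mL here

Compound 1 holds the lower of these two numbers. Compound 3 `N#Cc1ccc(S(=O)(=O)Nc2cccc3c(Cl)c[nH]c23)cc1` differs from it by one change, chloro in place of cyano on an aromatic carbon of a five-membered aromatic ring, two ring bonds from the ring nitrogen: chloro in place of cyano on an aromatic carbon is the full count. Going by the values given here, the only measured step, a 10-fold higher number from compound 1 to compound 2 (1.00 log units; beyond the scatter) in this assay, replaces the other cyano group, so it says little about this place. No step beyond the scatter is therefore expected, and the estimated change is a 1.3-fold higher number from compound 1 to compound 3 (0.10 log units; within the scatter) at most. Compound 3 is expected at 0.15 ug/mL (range 0.04 ug/mL to 0.6 ug/mL) in this assay here.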

Compound 3, half-maximal inhibitory concentration: 0.13 ug/mL
For compound 3 the middle estimate is 1.2-fold (0.06 log units) above the measured one, within the range that was stated.
By their numbers in this assay, from the lowest: compounds 1 and 3 (each within the scatter of the next); then compound 2.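

In this assay, chloro in place of cyano on an aromatic carbon of the five-membered aromatic ring gives a 1.1-fold higher number from compound 1 to compound 3 (0.03 log units; within the scatter), so at this position the change produces no step beyond the scatter. The earlier compounds shown here differed only at the other cyano group, so they gave no reading at this place. Nothing available here explains why the two groups read alike.

On these data alone, whether an amine or a carboxylic acid at this position would also stay within the scatter remains open. So does whether chloro here would read the same with methanesulfonamido replacing the other cyano group.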